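Carboxyphenyl in place of carboxypropyl: a step in the acid arm

This account rests on a few compounds, and the source may have more. Where it says the series, first, only, none or still open, it means among the compounds named here.

compound 1 `O=C(O)CCCCCCN1C(=O)CCC1CCC(O)CCc1ccccc1` — > 3200 nM in an assay on HEK293 cells for binding affinity to prostaglandin E2 receptor EP2 subtype (Rattus norvegicus); a higher number here means a weaker inhibitor, a lower number a stronger inhibitor
compound 2 `O=C(O)c1ccc(CCCN2C(=O)CCC2CCC(O)Cc2ccc(F)cc2)cc1` — > 3200 nM
compound 3 `O=C(O)CCCCCCN1C(=O)CCC1CCC(O)Cc1cccc(Cl)c1` — > 3200 nM

Compound 3 sits at the limit of this assay; its value is a limit, not a number. Compound 1 also gives only a limit. Compound 2 also gives only a limit, and it already carries the 4-carboxyphenyl arm together with a 4-fluorophenyl end. The step that the two limits leave unreadable from compound 1 to compound 3 is unreadable because both ends are limits (the limit of > 3200 nM in this assay, at which 3 of the 3 values shown sit).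

Compound 4 `O=C(O)c1ccc(CCCN2C(=O)CCC2CCC(O)Cc2cccc(Cl)c2)cc1` differs from compound 3 by 4-carboxyphenyl in place of 3-carboxypropyl on a saturated chain carbon, three bonds along the chain from an amide-type nitrogen in a ring. No measured step isolates this change, and every shown value is a limit. The step that the limit leaves unreadable from compound 3 to compound 4 is therefore expected to stay unreadable. Compound 4 is estimated at 6000 nM, with a range of 2500 nM to 20000 nM, most likely again reported as a limit.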

Compound 4, half-maximal inhibitory concentration: > 3200 nM
Compound 4: a limit, no number (the forecaster's own chance of this, stated with the estimate: 80%); the middle value does not contradict the limit.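

Neither the step from compound 3 to compound 4 nor the step from compound 2 to compound 4 can be read, because both ends of each are limits: the limit of > 3200 nM in this assay, at which 4 of the 4 values shown sit. On these data alone, whether any change in the acid arm or the phenyl end gives a measurable value stays open.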